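The source may hold more compounds than are shown below. What is called first, only, known or untested is meant among the compounds shown, and "the series" means these compounds.

Compound 1 `CN1CCN(CC(=O)N2CC3C(c4ccccc4)CC(N(C)C)(CC3c3ccccc3)C2)CC1` and compound 2 `CCN(CC)CCC(=O)N1CC2C(c3ccccc3)CC(N(C)C)(CC2c2ccccc2)C1` share one core and differ only in the group carried on the carbonyl-bearing chain. In an ADME assay on L6 cells (Rattus norvegicus) for cytotoxicity, read by resazurin assay, with a stated time of 72 h (a lower number here means a stronger inhibitor, a higher number a weaker inhibitor), compound 1 gives 9250 nM, and compound 2 gives 15400 nM. Going by the values given here, the only step between measured compounds, a 1.7-fold higher number from compound 1 to compound 2 (0.22 log units; within the scatter), changes nothing beyond the scatter, so compound 1 stands with the lower of the two numbers but not apart from compound 2.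

Compound 3 `CN(C)C12CC(c3ccccc3)C(CN(CCCN3CCCCC3)C1)C(c1ccccc1)C2` has not been measured in this assay. It differs from compound 1 by 3-(piperidin-1-yl)propyl in place of ((4-methylpiperazin-1-yl)methyl)carbonyl on an amine nitrogen in a ring. Among the compounds with values here, this change is of another kind than the one between compound 1 and compound 2: there the carbonyl and its neighbouring chain were kept and only the terminal amine was swapped, whereas here the carbonyl leaves with the whole group and a 3-(piperidin-1-yl)propyl takes its place on the amine nitrogen in the ring. Within the data shown here, the one measured step, a 1.7-fold higher number from compound 1 to compound 2 (0.22 log units; within the scatter), therefore bears on it only loosely and suggests that swapping one amine-bearing chain for another moves little. For compound 3 a step of a 1.9-fold lower number from compound 1 to compound 3 (0.27 log units; within the scatter) toward a lower number is expected, with wide uncertainty. Compound 3 is thus estimated at 5000 nM, within a range from 1500 nM to 16000 nM.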

Compound 3, half-maximal inhibitory concentration: 1750 nM
For compound 3 the middle estimate is 2.9-fold (0.46 log units) above the measured one; low and high end bracket the measured number.
By their numbers in this assay, from the lowest: compound 3; then compounds 1 and 2 (each within the scatter of the next).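

Taking away the whole carbonyl-bearing group on the amine nitrogen in the ring does what exchanging only its terminal amine did not: it moves the number beyond the scatter in this assay. With 3-(piperidin-1-yl)propyl in place of ((4-methylpiperazin-1-yl)methyl)carbonyl the result is a 5.3-fold lower number from compound 1 to compound 3 (0.72 log units; beyond the scatter), and with the same group in place of (2-(diethylamino)ethyl)carbonyl it is an 8.8-fold lower number from compound 2 to compound 3 (0.94 log units; beyond the scatter). Both steps run in the same direction, so this position on the shared core is not indifferent to what it carries, even though compound 1 and compound 2 alone gave no sign of that.

The step to compound 3 removes the carbonyl and changes the terminal amine in one move, so the compounds shown cannot say which of the two carries the lower number; a 3-(4-methylpiperazin-1-yl)propyl or a 3-(diethylamino)propyl chain on the same nitrogen would separate them, and a shorter or longer chain ending in piperidine would test the length of the link. No measurement at hand explains the shift in the number.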